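This account rests on a few compounds, and the source may have more. Where it says the series, first, only, none or still open, it means among the compounds named here.

Compounds measured so far in a physicochemical assay for solubility, read by HPLC, in phosphate buffer, measured as thermodynamic solubility, with a stated time of 24 h, at pH 7.4; a lower number here means a less soluble compound, a higher number a more soluble compound:

Compound 1 `C[C@@H]1CN([C@@H](C)CO)C(=O)c2cccc(NC(=O)N(C)c3cccc4ccccc34)c2O[C@H]1CN(C)S(=O)(=O)c1ccc2c(c1)OCCO2` gives 11200 nM in this assay.
Compound 2 `C[C@@H]1CN([C@@H](C)CO)C(=O)c2cccc(NC(=O)Nc3nccc4ccccc34)c2O[C@H]1CN(C)S(=O)(=O)c1ccc2c(c1)OCCO2` gives 700 nM in this assay.
Compound 3 `C[C@@H]1CN([C@@H](C)CO)C(=O)c2cccc(NC(=O)Nc3ccnc4ccccc34)c2O[C@H]1CN(C)S(=O)(=O)c1ccc2c(c1)OCCO2` gives 30300 nM in this assay.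

Compound 3 stands at the top of the three numbers: a 2.7-fold higher number from compound 1 to compound 3 (0.43 log units; beyond the scatter) marks a modest gain, and a 43-fold higher number from compound 2 to compound 3 (1.64 log units; beyond the scatter) a large one. The other step, a 16-fold lower number from compound 1 to compound 2 (1.20 log units; beyond the scatter), is large in the downward direction.

Compound 4 `C[C@@H]1CN([C@@H](C)CO)C(=O)c2cccc(NC(=O)Nc3cccc4ncccc34)c2O[C@H]1CN(C)S(=O)(=O)c1ccc2c(c1)OCCO2` carries a different placement of the same atoms: quinolin-5-yl in place of quinolin-4-yl on an amide-type nitrogen. Among the compounds with values here, no measured step moves a nitrogen within a quinolin-yl or isoquinolin-yl group in this way, so the bearing steps are indirect. The step from compound 2 to compound 3 shows that shifting the nitrogen within an otherwise identical bicyclic group can move the number by a large amount, while the step from compound 1 to compound 3 shows that a carbon-only bicycle with a methyl on the amide-type nitrogen sits modestly below compound 3. A quinolin-5-yl group keeps the nitrogen away from the attachment ring; a step downward from compound 3, of modest size, is therefore expected, as a 3.0-fold lower number from compound 3 to compound 4 (0.48 log units; beyond the scatter).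

Compound 4 is estimated at 10000 nM in this assay, within a range of 2500 nM to 40000 nM.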

Compound 4, solubility: 139000 nM
For compound 4 the middle estimate is 14-fold (1.14 log units) below the measured one; the measured number lies above the stated range.
By their numbers in this assay, from the lowest: compound 2; then compound 1; then compound 3; then compound 4.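

In this assay, replacing quinolin-4-yl with quinolin-5-yl on the amide-type nitrogen gives a 4.6-fold higher number from compound 3 to compound 4 (0.66 log units; beyond the scatter), so a nitrogen shift within the group still moves the number beyond the scatter, and in the upward direction, although heavy-atom, donor and acceptor counts stay the same. The same group also stands clear of the other two compounds, with a 200-fold higher number from compound 2 to compound 4 (2.30 log units; beyond the scatter) and a 12-fold higher number from compound 1 to compound 4 (1.09 log units; beyond the scatter), which places compound 4 highest of the four and stretches the range at this position well past what the first three compounds showed. No measurement at hand accounts for this order of the numbers.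

Compound 1 differs from the others both in its carbon-only bicycle and in the methyl on the amide-type nitrogen, so the shares of those two features remain unseparated, and whether that methyl would raise or lower the number for the quinolin-5-yl group is open. Also open, from the compounds shown here alone, is how far the number would move with a single-ring pyridinyl group at this place, or with an added amine or carboxylic acid on the quinolin-5-yl group.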